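Solubility notes on compounds 1 to 4 of the series

The source may report more compounds than this note shows. Statements on the series, on what has been measured and on what is new or still open speak of the compounds shown alone.

Of the compounds shown here, three have been measured in a physicochemical assay for solubility, read by LC-MS, in phosphate buffer, measured as kinetic solubility, with a stated time of 24 h, at 25 degrees C, at pH 7.4; a higher number here means a more soluble compound, a lower number a less soluble compound. Compound 1 `Nc1nccc(-c2cc(OC3CCOC3)c3c(N)n[nH]c3c2)n1` gives 751000 nM and stands highest of the three numbers. Compound 2 `Nc1cc(-c2ccc3c(N)n[nH]c3c2)nc(N)n1` gives 58000 nM, the nearest of the other numbers, and the gap from compound 1 lies beyond the scatter. Compound 3 `Nc1nccc(-c2ccc3c(Nc4ccccc4)n[nH]c3c2)n1` gives 3000 nM, the furthest number, and this gap from compound 1 also lies beyond the scatter. Compound 2 and compound 3 each differ from compound 1 in more than one place, so their values are taken only as they stand and no single change is read from them.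

Compound 4 `Nc1nccc(-c2cc(OCc3ccccc3)c3c(N)n[nH]c3c2)n1` is not yet measured in this assay. It differs from compound 1 in one place: benzyl in place of oxolan-3-yl on an oxygen on an aromatic ring. Within the data shown here, no measured pair carries this same change, so the size of the step is not anchored by a measured step. The expectation for the step is a lower number, beyond the scatter, estimated as a 10-fold lower number from compound 1 to compound 4 (1.00 log units; beyond the scatter). For compound 4 the estimated value is 75000 nM, with an expected range from 15000 nM to 300000 nM.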

Compound 4, solubility: 85000 nM
Estimate against measurement, compound 4: 1.1-fold (0.05 log units) below; measured number inside the range.
By their numbers in this assay, from the lowest: compound 3; then compounds 2 and 4 (each within the scatter of the next); then compound 1.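

In this assay the series now has its first step that can be read at a single place: an 8.8-fold lower number from compound 1 to compound 4 (0.95 log units; beyond the scatter), with benzyl in place of oxolan-3-yl on an oxygen on an aromatic ring. The earlier compounds shown here differ from one another in more than one place, so they could not show that a change at this oxygen alone moves the number beyond the scatter; this pair shows that it does, and that compound 4, with a six-membered aromatic ring of carbon only on this oxygen, still gives 85000 nM. The step is measured but not explained, as nothing on record bears on the reason for it.

With a single pair at this place, there is no way to tell how far the step would carry over to other groups on the same oxygen, such as a plain methyl, a longer chain ending in an amine, or a chain ending in a carboxylic acid. As far as these compounds go, it also remains open whether the same exchange would give a step of similar size on a core other than that of compound 1.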